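Chloro added to a phenyl ring of compound 2

A few compounds are considered here, and "the series" means these few. Any claim that something is new, unique, unknown or untested is made for them only; others in the source may bear on it.

Measured in a functional assay on PC-3 cells (Homo sapiens) for antiproliferative activity, read by MTT assay, with a stated time of 48 h; on this read-out higher numbers stand for weaker inhibition and lower numbers for stronger inhibition:
compound 1 `O=C(/C=C\Nc1ccc(C(F)(F)F)cc1)c1cn(-c2ccccc2)nc1-c1ccccc1`: > 50000 nM, a limit
compound 2 `O=C(/C=C\Nc1ccc(O)cc1)c1cn(-c2ccccc2)nc1-c1ccccc1`: 3600 nM

Within the data shown here, compound 2 holds the only actual number so far, and the limit of > 50000 nM in this assay, at which 1 of the 2 values shown sits, is where compound 1 sits. Among the measured compounds shown here, the only measured step, an at least 13-fold lower number from compound 1 to compound 2 (1.14 log units; beyond the scatter), is large, but it puts hydroxy in place of trifluoromethyl, a different change, so it sets no size here. Compound 3 `O=C(/C=C\Nc1ccc(O)cc1)c1cn(-c2ccccc2)nc1-c1ccc(Cl)cc1` differs from compound 2 by chloro in place of hydrogen on an aromatic carbon, which is phenyl to 4-chlorophenyl. For the measured compounds named here, with no measured step covering this change, no shift beyond the scatter is expected in this assay. The expected change is a 1.2-fold lower number from compound 2 to compound 3 (0.08 log units; within the scatter). Compound 3 is estimated at 3000 nM, with an expected range of 800 nM to 12000 nM.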

Compound 3, half-maximal inhibitory concentration: 4430 nM
For compound 3 the middle estimate is 1.5-fold (0.17 log units) below the measured one, and the stated range covers the measured number.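

Phenyl to 4-chlorophenyl in this assay gives a 1.2-fold higher number from compound 2 to compound 3 (0.09 log units; within the scatter). Compounds 1 and 2 had shown change only at the hydroxy-bearing ring, and this result adds that a chloro, para to a large group on this other ring, brings no shift beyond the scatter. Nothing measured here speaks to the reason for this.

As far as these compounds go, it remains open whether an amine, a methoxy or a carboxylic acid at this place would move the number beyond the scatter. From the compounds shown here alone, it also remains open whether chloro on the other unsubstituted phenyl of the shared core would leave the number equally unmoved.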